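The compounds below may be only part of what the source reports. "The series", "measured", "known", "first", "only" and "open" are said of these compounds alone.

Three compounds have been measured in a toxicity assay on Vero cells (Chlorocebus sabaeus) for cytotoxicity; a lower number here means that less compound is tolerated, a higher number that more compound is tolerated:

compound 1 `O=C(/C=C/c1ccc([N+](=O)[O-])o1)c1ccc(Cl)cc1` gives 558000 nM;
compound 2 `O=C(/C=C/c1ccc([N+](=O)[O-])o1)c1ccc(Cl)cc1Cl` gives 417000 nM;
compound 3 `O=C(/C=C/c1ccc([N+](=O)[O-])o1)c1ccco1` gives 776000 nM.

In this assay compound 1 stands second highest of the three numbers. Its nearest neighbour is compound 2 and its furthest is compound 3, and both gaps lie within the scatter of repeated measurements, so the three numbers cannot be told apart. Within the data shown here, the one step that can be read between compounds differing in a single place, a 1.3-fold lower number from compound 1 to compound 2 (0.13 log units; within the scatter), is likewise within the scatter.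

Compound 4 `C=C(C)COc1ccc(C(=O)/C=C/c2ccc([N+](=O)[O-])o2)cc1` differs from compound 1 in one place: (2-methylprop-2-en-1-yl)oxy in place of chloro on an aromatic carbon. Among the measured compounds shown here, no measured step in this set concerns this exchange; the only step available, a 1.3-fold lower number from compound 1 to compound 2 (0.13 log units; within the scatter), shows that altering the substitution on the same ring left the number within the scatter. On that basis compound 4 is expected to stay close to compound 1, with a step of about a 1.1-fold lower number from compound 1 to compound 4 (0.05 log units; within the scatter), no change beyond the scatter. The estimate for compound 4 is 500000 nM, within a range from 220000 nM to 1100000 nM.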

Compound 4, half-maximal cytotoxic concentration: 393000 nM
The estimate for compound 4 lay 1.3-fold (0.10 log units) above the measured number; the range from low to high includes it.
By their numbers in this assay, from the lowest: compounds 4, 2, 1 and 3 (each within the scatter of the next).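

In this assay, the only step shown that replaces the chloro on the aromatic carbon para to a large group is the exchange for (2-methylprop-2-en-1-yl)oxy, which gives a 1.4-fold lower number from compound 1 to compound 4 (0.15 log units; within the scatter) and so stays within the scatter. Compound 2 had left that chloro in place, whereas this change swaps a single heavy atom for a chain of 5 heavy atoms that brings a double bond and a hydrogen-bond acceptor, and the number still cannot be told apart from that of compound 1. Nothing available explains why this exchange leaves the number within the scatter.

The compounds shown leave open whether this position would tolerate an amine or a carboxylic acid equally well. They also leave open how a longer chain or a simple methoxy group would read in this assay at the same place.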